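A few compounds are considered here, and "the series" means these few. Any claim that something is new, unique, unknown or untested is made for them only; others in the source may bear on it.

Measured so far in an ADME assay on HeLa cells (Homo sapiens) for cytotoxicity, read by MTT assay, with a stated time of 24 h; a lower number here means a stronger inhibitor, a higher number a weaker inhibitor:
- compound 1 `CCSC(=S)N1CCN(C(=S)SC(=S)N(C)C)CC1` gives 4480000 nM
- compound 2 `CN(C)C(=S)SC(=S)N1CCN(C(=S)SCc2ccccc2)CC1` reaches only the assay limit of > 5000000 nM
- compound 3 `CCCCNC(=S)N1CCN(C(=S)SC(=S)N(C)C)CC1` gives 2840000 nM

Compound 3 has the lowest of the two actual numbers; its nearest neighbour is compound 1, and the step of a 1.6-fold lower number from compound 1 to compound 3 (0.20 log units; within the scatter) stays within the ordinary scatter of the measurement. Compound 4 `CN(C)C(=S)SC(=S)N1CCN(C(=S)Nc2ccccc2)CC1` is the next compound, and it differs from compound 3 by phenyl in place of butyl on an amide-type nitrogen.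

Among the measured compounds shown here, two measured steps bear on this change. One adds a phenyl ring elsewhere in the shared core: the step of an at least 1.1-fold higher number from compound 1 to compound 2 (0.04 log units; that floor lies within the scatter) is tiny, and it ends at the limit of the assay (the limit of > 5000000 nM in this assay, at which 1 of the 3 values shown sits), so it only bounds the effect. The other swaps a sulfur-linked group for the butylamino group: an at least 1.7-fold lower number from compound 2 to compound 3 (0.24 log units; that floor lies within the scatter), again not beyond the scatter. Neither step gives a reason to expect a change beyond the scatter in this assay.

Compound 4 is therefore estimated at 3200000 nM, with a likely range from 1200000 nM to 8000000 nM. That estimate means an expected step of a 1.1-fold higher number from compound 3 to compound 4 (0.05 log units; within the scatter), essentially flat.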

Compound 4, half-maximal inhibitory concentration: > 5000000 nM
Compound 4: a limit, no number; the forecaster's own chance of this, stated with the estimate: 25%; middle value at least 1.5-fold (0.19 log units) away from the limit.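

Compound 4 puts an aromatic ring on the amide-type nitrogen where compound 3 has a butyl group, and in this assay this gives only a floor for the change: an at least 1.7-fold higher number from compound 3 to compound 4 (0.24 log units; that floor lies within the scatter). Set against the ethylsulfanyl group of compound 1, the anilino group also gives only a floor: an at least 1.1-fold higher number from compound 1 to compound 4 (0.04 log units; that floor lies within the scatter). The value of compound 4 is a limit and not a number, the step involving compound 2 cannot be read, and the assay ceiling now holds more of the compounds shown: the limit of > 5000000 nM in this assay, at which 2 of the 4 values shown sit.

As far as these compounds go, how far compound 4 really lies from compound 3 stays open, so the true size of the phenyl effect is unknown. Also open, from the compounds shown here alone, is how a cyclohexyl ring, or a phenyl ring carrying a methoxy group, would read on this nitrogen.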